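Working notes on the series: estimating compound 3

A few compounds are considered here, and "the series" means these few. Any claim that something is new, unique, unknown or untested is made for them only; others in the source may bear on it.

Measured so far:
compound 1, `O=S(=O)(NCCCNCc1ccccc1)c1cc(C(F)(F)F)cc(C(F)(F)F)c1`, gives 14000 nM in a functional assay on Capan-2 cells (Homo sapiens) for inhibition, read by MTT assay, with a stated time of 72 h; a lower number here means a stronger inhibitor of growth, a higher number a weaker inhibitor of growth.
compound 2, `COc1ccc(CNCCCNS(=O)(=O)c2cc(C(F)(F)F)cc(C(F)(F)F)c2)cc1`, gives 2400 nM in this assay.

Within the data shown here, compound 2 stands at the lowest of the two numbers in this assay; the only neighbour is compound 1, and the step of a 5.8-fold lower number from compound 1 to compound 2 (0.77 log units; beyond the scatter) separates them, which is beyond the scatter. That step is a methoxy in place of hydrogen on an aromatic carbon.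

Compound 3, `O=S(=O)(NCCCNCc1cccc(Cl)c1)c1cc(C(F)(F)F)cc(C(F)(F)F)c1`, differs from compound 2 by 3-chlorophenyl in place of 4-methoxyphenyl on a saturated chain carbon bound to an amine nitrogen. Among the measured compounds shown here, only the single step from compound 1 to compound 2 bears on this change, and it bears only in part: it shows what the methoxy contributed relative to hydrogen, whereas nothing in the data shows what a chlorine on that ring does. Removing the methoxy is therefore expected to give up some of the gain seen in the step of a 5.8-fold lower number from compound 1 to compound 2 (0.77 log units; beyond the scatter), while the chlorine is an unknown that could offset or widen that loss. The expected outcome for compound 3 is a moderately higher number, a 2.1-fold higher number from compound 2 to compound 3 (0.32 log units; beyond the scatter), with wide uncertainty. The estimate for compound 3 in this assay is 5000 nM, ranging from 1500 nM to 16000 nM.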

Compound 3, concentration for 50% growth inhibition: 8000 nM
For compound 3 the middle estimate is 1.6-fold (0.20 log units) below the measured one; the measured number falls inside the stated range.
By their numbers in this assay, from the lowest: compound 2; then compounds 3 and 1 (each within the scatter of the next).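

In this assay the chloro in place of hydrogen gives a 1.8-fold lower number from compound 1 to compound 3 (0.24 log units; within the scatter) and so leaves the 3-chlorophenyl group of compound 3 indistinguishable from the unsubstituted phenyl group of compound 1 at this place. Read with a 5.8-fold lower number from compound 1 to compound 2 (0.77 log units; beyond the scatter) and with a 3.3-fold higher number from compound 2 to compound 3 (0.52 log units; beyond the scatter) as its counterpart, this leaves compound 2 with the lowest number of the three, separated from compound 1 and from compound 3 by steps beyond the scatter, and its 4-methoxyphenyl group is the only ring tested here on a saturated chain carbon bound to an amine nitrogen that stands apart. No measurement is available that accounts for this difference.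

The step from compound 2 to compound 3 changes both the group and where it sits on the ring, so a 4-chlorophenyl or a 3-methoxyphenyl group would be needed to separate those two changes. On these data alone, how an amine or a carboxylic acid on that ring would read remains open, as does the effect of a longer chain in the shared core.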